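Stereocentre inversion from compound 2 to compound 4

The source may hold more compounds than are shown below. What is called first, only, known or untested is meant among the compounds shown, and "the series" means these compounds.

Measured in a functional assay on Lu1 cells (Homo sapiens) for cytotoxicity; on this read-out lower numbers stand for an effect already at smaller amounts and higher numbers for an effect only at larger amounts of compound:
Compound 1, `CCC[C@@H](OC(C)=O)C1=C(Br)/C(=C/Br)OC1=O`, gives 1.7 ug/mL.
Compound 2, `CCC[C@@H](OC(C)=O)C1=C(Br)[C@@](OC)(C(Br)Br)OC1=O`, reaches only the assay limit of > 20 ug/mL.
Compound 3, `CCCCC1=C(Br)/C(=C/Br)OC1=O`, likewise reaches only the assay limit of > 20 ug/mL.

Compound 2 thus stands at the limit of > 20 ug/mL in this assay, at which 2 of the 3 values shown sit, with no number of its own. Compound 4, `CCC[C@@H](OC(C)=O)C1=C(Br)[C@](OC)(C(Br)Br)OC1=O`, differs from compound 2 in this way: the two compounds have the same atoms and bonds and differ only in configuration as drawn: 1 of 2 stereo elements differ; a stereocentre at a saturated ring carbon is drawn S in compound 2 and R in compound 4. For the measured compounds named here, the only measured step, an at least 11-fold higher number from compound 1 to compound 3 (1.07 log units; beyond the scatter), concerns a different change and no measured pair differs solely in configuration, so it gives no guide here. No step beyond the scatter is expected: a number no higher from compound 2 to compound 4 (the limit leaves the size open). Compound 4 is therefore estimated at 20 ug/mL (range 10 ug/mL to 40 ug/mL), most probably reported again as a limit.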

Compound 4, concentration for half-maximal effect: > 20 ug/mL
Compound 4 was reported as a limit; the forecaster's own chance of this, stated with the estimate: 75%; the middle value sits exactly at the limit.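

For the compounds shown here, compound 2 and compound 4 are both reported only as limits in this assay, so no step between them can be read. As far as these compounds go, whether the configuration at the saturated ring carbon matters for this read-out stays open.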